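This account rests on a few compounds, and the source may have more. Where it says the series, first, only, none or still open, it means among the compounds named here.

Measured compounds:
- compound 1 `O=C(Nc1ccc(CN2CCCC2)cc1)Nc1ccc2ncnc(Nc3cccc(C(F)(F)F)c3)c2c1` — 1360 nM
- compound 2 `CCN(CC)Cc1ccc(NC(=O)Nc2ccc3ncnc(Nc4cccc(C(F)(F)F)c4)c3c2)cc1` — 3980 nM
- compound 3 `Cc1ccc(NC(=O)Nc2ccc3ncnc(Nc4cccc(C(F)(F)F)c4)c3c2)cc1` — > 10000 nM

Three ureas sharing the core of compound 1 have been tested in a functional assay on A-431 cells (Homo sapiens) for antiproliferative activity, read by MTT assay, with a stated time of 72 h; a higher number here means a weaker inhibitor, a lower number a stronger inhibitor. Compound 1 gives 1360 nM, and compound 2 gives 3980 nM. Among the measured compounds shown here, for compound 3 the assay reports only a limit, > 10000 nM; this is the one value sitting at the limit of > 10000 nM in this assay, at which 1 of the 3 values shown sits, so compound 3 stands weakest of the three as far as the numbers go, with its true value unknown beyond that limit. Going from compound 1 to compound 2 cost a 2.9-fold higher number from compound 1 to compound 2 (0.47 log units; beyond the scatter), from compound 1 to compound 3 an at least 7.3-fold higher number from compound 1 to compound 3 (0.86 log units; beyond the scatter), and from compound 2 to compound 3 an at least 2.5-fold higher number from compound 2 to compound 3 (0.40 log units; beyond the scatter).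

Compound 4 `CCN(CC)c1ccc(NC(=O)Nc2ccc3ncnc(Nc4cccc(C(F)(F)F)c4)c3c2)cc1` is not yet measured. It differs from compound 3 by diethylamino in place of methyl on an aromatic carbon. The measured steps that bear on it are the ones removing or swapping the amine on the saturated chain carbon, where the diethylamino group was worth an at least 2.5-fold higher number from compound 2 to compound 3 (0.40 log units; beyond the scatter) against hydrogen. The change here puts diethylamino straight onto the aromatic carbon, so that evidence transfers only loosely. Compound 4 is expected to improve on compound 3 by about an at least 1.6-fold lower number from compound 3 to compound 4 (0.22 log units; that floor lies within the scatter), and its value is estimated at 6000 nM, within 2000 nM to 20000 nM.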

Compound 4, half-maximal inhibitory concentration: 6460 nM
Estimate against measurement, compound 4: 1.1-fold (0.03 log units) below; the range from low to high includes it.
By their numbers in this assay, from the lowest: compound 1; then compounds 2 and 4 (each within the scatter of the next). At a limit, above all of these: compound 3.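

With diethylamino set straight on the aromatic carbon, this assay shows an at least 1.5-fold lower number from compound 3 to compound 4 (0.18 log units; that floor lies within the scatter), and this is only a floor, since the value of compound 3 is a limit: the limit of > 10000 nM in this assay, at which 1 of the 4 values shown sits.

The saturated chain carbon of the (diethylamino)methyl group turns out not to be required at this position, for the step reads a 1.6-fold higher number from compound 2 to compound 4 (0.21 log units; within the scatter), which leaves compound 2 and compound 4 indistinguishable in this assay. The (pyrrolidin-1-yl)methyl group of compound 1 nevertheless keeps a real lead over the directly attached diethylamino, with a 4.8-fold higher number from compound 1 to compound 4 (0.68 log units; beyond the scatter), so the gain at this position depends on more than the presence of an amine alone.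

As far as these compounds go, what remains open is whether pyrrolidin-1-yl set directly on the aromatic carbon would match compound 1 or fall back towards compound 4, since the two changes of amine and of chain carbon are tied together in that comparison. The compounds shown also say nothing about a longer chain carrying the amine, or about a morpholin-4-yl or 4-methylpiperazin-1-yl group at this place.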